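Compound 3 to Compound 4: a Decyl Chain Enters

The source may hold more compounds than are shown below. What is called first, only, known or untested is meant among the compounds shown, and "the series" means these compounds.

The three measured compounds, all tested in a functional assay on HepG2 cells (Homo sapiens) for antiproliferative activity, read by MTT assay, with a stated time of 72 h; on this read-out lower numbers stand for stronger inhibition and higher numbers for weaker inhibition:
compound 1, `COc1ccc(-c2cn(C[C@H](O)[C@H]3OC(=O)C(OCc4ccccc4)=C3OCc3ccccc3)nn2)cc1`, gives 46400 nM;
compound 2, `O=C1O[C@H]([C@@H](O)Cn2cc(CCO)nn2)C(OCc2ccccc2)=C1OCc1ccccc1`, gives 68100 nM;
compound 3, `COc1ccccc1-c1cn(C[C@H](O)[C@H]2OC(=O)C(OCc3ccccc3)=C2OCc2ccccc2)nn1`, gives only a limit, > 100000 nM.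

Compound 3 therefore stands at the top of the numbers shown: its value is a limit of this assay and not a number, as noted in the limit of > 100000 nM in this assay, at which 1 of the 3 values shown sits. Among the measured steps, an at least 2.1-fold higher number from compound 1 to compound 3 (0.33 log units; beyond the scatter), while an at least 1.4-fold higher number from compound 2 to compound 3 (0.16 log units; that floor lies within the scatter) and a 1.5-fold higher number from compound 1 to compound 2 (0.17 log units; within the scatter). So the two compounds with an aryl group on the five-membered aromatic ring with 3 nitrogen differ modestly, and the 2-hydroxyethyl compound sits between them.

Compound 4, `CCCCCCCCCCc1cn(C[C@H](O)[C@H]2OC(=O)C(OCc3ccccc3)=C2OCc2ccccc2)nn1`, differs from compound 3 by decyl in place of 2-methoxyphenyl on an aromatic carbon. Going by the values given here, none of the measured steps involves a decyl group, so no step bears directly on this change; the steps all lie within or just beyond the scatter, and compound 3 offers only a limit to start from. The step is therefore expected to be small or uncertain in direction, estimated as an at least 2.0-fold lower number from compound 3 to compound 4 (0.30 log units; that floor lies within the scatter). Compound 4 is expected to give about 50000 nM in this assay, within a range from 15000 nM to 200000 nM.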

Compound 4, half-maximal inhibitory concentration: 12200 nM
The estimate for compound 4 lay 4.1-fold (0.61 log units) above the measured number; measured number outside the range, below it.
By their numbers in this assay, from the lowest: compound 4; then compounds 1 and 2 (each within the scatter of the next). At a limit, above all of these: compound 3.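

At this aromatic carbon, next to the ring nitrogen, the earlier compounds had shown that the chain of compound 2 and the aryl group of compound 1 could not be told apart, as a 1.5-fold higher number from compound 1 to compound 2 (0.17 log units; within the scatter) stays within the scatter. A decyl chain, which has no ring and no hydrogen-bond acceptor, now gives a clear separation in this assay, with a 3.8-fold lower number from compound 1 to compound 4 (0.58 log units; beyond the scatter) and a 5.6-fold lower number from compound 2 to compound 4 (0.75 log units; beyond the scatter), so compound 4 has the lowest number of the four, and the 2-hydroxyethyl chain of compound 2 shows that a chain alone does not bring this about. Compound 3 gives only a limit, so an at least 8.1-fold lower number from compound 3 to compound 4 (0.91 log units; beyond the scatter) marks a floor for that step and not its full size: the limit of > 100000 nM in this assay, at which 1 of the 4 values shown sits.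

The compounds shown leave open whether the lower number follows the length of the chain, as decyl and 2-hydroxyethyl are the only two chains here and they differ in both length and their hydroxy group. A hexyl or dodecyl chain would test the length, and a decyl chain ending in an amine or a carboxylic acid would show whether the end of the chain matters.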